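Trifluoromethoxy for trifluoromethyl on a very weak inhibitor

A few compounds are considered here, and "the series" means these few. Any claim that something is new, unique, unknown or untested is made for them only; others in the source may bear on it.

Compound 1 `Oc1cccc(-c2cc(-c3cccc(C(F)(F)F)c3)cc(-c3ccccc3O)n2)c1` is measured in a functional assay on DU-145 cells (Homo sapiens) for inhibition (a lower number here means a stronger inhibitor, a higher number a weaker inhibitor), where compound 1 gives 13000 nM. Compound 2 `Oc1ccc(-c2cc(-c3cccc(C(F)(F)F)c3)cc(-c3ccccc3O)n2)cc1` carries a 4-hydroxyphenyl in place of the 3-hydroxyphenyl of compound 1. In this assay compound 2 reaches only the limit of > 50000 nM, which is a limit of the assay and not a number. The step of an at least 3.8-fold higher number from compound 1 to compound 2 (0.58 log units; beyond the scatter) is therefore known only as a lower bound, because of the limit of > 50000 nM in this assay, at which 1 of the 2 values shown sits.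

Compound 3 `Oc1ccc(-c2cc(-c3cccc(OC(F)(F)F)c3)cc(-c3ccccc3O)n2)cc1` differs from compound 2 at another place: trifluoromethoxy in place of trifluoromethyl on an aromatic carbon. Going by the values given here, none of the measured steps concerns this change; the one measured step moves the hydroxyl on a different ring and says nothing about the trifluoromethyl group. With no evidence bearing on the exchange, the step from compound 2 to compound 3 in this assay is expected to stay within the scatter, as a step that the limit leaves unreadable from compound 2 to compound 3. Compound 3 is accordingly estimated at 70000 nM, within a range from 30000 nM to 200000 nM, and it is likely that this assay again reports only a limit for compound 3.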

Compound 3, half-maximal inhibitory concentration: > 50000 nM
Compound 3: only a limit was reported; the forecaster's own chance of this, stated with the estimate: 75%; the middle value does not contradict the limit.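

In this assay compound 3 gives > 50000 nM, which is a limit of the assay and not a number. Going by these compounds alone, compound 2 stands at the same limit, so no step from trifluoromethyl to trifluoromethoxy can be read between the two: the limit of > 50000 nM in this assay, at which 2 of the 3 values shown sit. The compounds shown leave open whether this exchange changes inhibition at all.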